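The compounds below may be only part of what the source reports. "The series", "measured", "known", "first", "only" and "open" are said of these compounds alone.

In an ADME assay (liver) for metabolic stability, with Liver microsome (Rattus norvegicus) as the target, using microsomes and NADPH, with a stated time of 30 min, tested at 1 uM (a lower number here means slower removal, a higher number faster removal of the compound), compound 1 (`Nc1ccc(S(=O)(=O)N2CCN(c3ncc(C(O)(C(F)(F)F)C(F)(F)F)cc3Br)CC2)cn1`) gives 32 mL.min-1.g-1 and compound 2 (`Nc1ccc(S(=O)(=O)N2CCN(c3ncc(C(O)(C(F)(F)F)C(F)(F)F)cc3-c3cccc(F)c3)CC2)cn1`) gives 52 mL.min-1.g-1, while compound 3 (`Nc1ccc(S(=O)(=O)N2CCN(c3ncc(C(O)(C(F)(F)F)C(F)(F)F)cc3-c3ccc4ocnc4c3)CC2)cn1`) gives 120 mL.min-1.g-1 as the highest of the three numbers. Compound 4 (`Nc1ccc(S(=O)(=O)N2CCN(c3ncc(C(O)(C(F)(F)F)C(F)(F)F)cc3-c3cc4ccccc4s3)CC2)cn1`), not yet measured, carries 1-benzothiophen-2-yl in place of 1,3-benzoxazol-5-yl on an aromatic carbon. Within the data shown here, no measured step makes this exact swap. The nearest are a 1.6-fold higher number from compound 1 to compound 2 (0.21 log units; within the scatter) for 3-fluorophenyl in place of bromo, a 3.8-fold higher number from compound 1 to compound 3 (0.57 log units; beyond the scatter) for 1,3-benzoxazol-5-yl in place of bromo and a 2.3-fold higher number from compound 2 to compound 3 (0.36 log units; beyond the scatter) for 1,3-benzoxazol-5-yl in place of 3-fluorophenyl. These steps are modest at most and give no direction for the new swap, so the expected change is small: a 1.2-fold higher number from compound 3 to compound 4 (0.07 log units; within the scatter) in this assay would stay within the scatter. For compound 4 the estimated value is 140 mL.min-1.g-1 with a range from 70 mL.min-1.g-1 to 280 mL.min-1.g-1 as the expected span.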

Compound 4, intrinsic clearance in microsomes: 315 mL.min-1.g-1
The estimate for compound 4 lay 2.3-fold (0.35 log units) below the measured number, outside the stated range (above it).
By their numbers in this assay, from the lowest: compounds 1 and 2 (each within the scatter of the next); then compound 3; then compound 4.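

In this assay, among these compounds, the group on this aromatic carbon matters more than the earlier compounds showed: replacing 1,3-benzoxazol-5-yl with 1-benzothiophen-2-yl, which has the same heavy-atom count, gives a 2.6-fold higher number from compound 3 to compound 4 (0.42 log units; beyond the scatter). Against 3-fluorophenyl and bromo the gap is wider, with a 6.1-fold higher number from compound 2 to compound 4 (0.78 log units; beyond the scatter) and a 9.8-fold higher number from compound 1 to compound 4 (0.99 log units; beyond the scatter), which places compound 4 highest of the four. No measurement at hand accounts for this rise.

On these data alone, the two groups differ in both their ring atoms and their point of attachment, so which of these matters stays open. So does the outcome with an amine or a carboxylic acid here.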